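The compounds below may be only part of what the source reports. "The series", "measured", "known", "first", "only" and "open" are said of these compounds alone.

Compound 1 `CCCCSc1nc(N)nc2c1ncn2/C=C1/CC1(CO)CO` is the starting point of this account. In an ADME assay on Akata cells (Homo sapiens) for cytotoxicity, with a stated time of 7 days (a lower number here means that less compound is tolerated, a higher number that more compound is tolerated), compound 1 gives > 20000 nM, which is a limit of the assay and not a number. Compound 2 `CN(C)c1nc(N)nc2c1ncn2/C=C1/CC1(CO)CO` gives > 24000 nM, likewise a limit. Compound 3 `Nc1nc(NC2CCCC2)c2ncn(/C=C3/CC3(CO)CO)c2n1` gives > 20000 nM, also a limit. The steps a step that the two limits leave unreadable from compound 1 to compound 2, a step that the two limits leave unreadable from compound 1 to compound 3 and a step that the two limits leave unreadable from compound 2 to compound 3 each join two limits, so none of them can be read; the limit of > 20000 nM in this assay, at which 2 of the 3 values shown sit, and the limit of > 24000 nM in this assay, at which 1 of the 3 values shown sits, are all the evidence there is. Compound 4 `CSc1nc(N)nc2c1ncn2/C=C1/CC1(CO)CO` differs from compound 1 by hydrogen in place of propyl on a saturated chain carbon bound to a sulfur. The measured steps all exchange the whole butylsulfanyl group and all are unreadable, so no step beyond the scatter is expected in this assay, and a limit is expected again. The expected step is a step that the limit leaves unreadable from compound 1 to compound 4. Compound 4 is estimated at 30000 nM, between 12000 nM and 100000 nM.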

Compound 4, half-maximal cytotoxic concentration: > 20000 nM
Compound 4 gave a limit, no number; the forecaster's own chance of this, stated with the estimate: 85%; the middle value lies beyond the limit too.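

Compound 4 gives a limit, as do compounds 1, 2 and 3, so none of the steps joining compound 4 to them can be read in this assay. The compounds shown leave open whether exchanging these groups changes the half-maximal cytotoxic concentration at all.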